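The source may report more compounds than this note shows. Statements on the series, on what has been measured and on what is new or still open speak of the compounds shown alone.

Of the compounds shown here, three have so far been measured in an ADME assay on HepG2 2.2.15 cells (Homo sapiens) for cytotoxicity, read by MTT assay, with stated times of 3 days and 7 days; on this read-out lower numbers stand for higher toxicity in this test and higher numbers for lower toxicity in this test.

Compound 1 `COc1ccc(-c2cc(C(=O)OCc3ccccc3)c3ccccc3n2)cc1` gives > 20000 nM in this assay, which is a limit of the assay rather than a number.
Compound 2 `Cc1ccc(-c2cc(C(=O)N3CCC(Cc4ccccc4)CC3)c3ccccc3n2)cc1` gives > 20000 nM, again a limit and not a number.
Compound 3 `O=C(OCc1ccc(Cl)cc1)c1cc(-c2ccccc2)nc2ccccc12` gives > 20000 nM, likewise a limit.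

Compound 2 thus stands exactly where the other two measured compounds stand: at the limit of > 20000 nM in this assay, at which 3 of the 3 values shown sit. For the measured compounds named here, no measured pair in this set differs in a single place, so no step between measured compounds can be read from these values, and nothing here separates one compound from another.

Compound 4 `CCOc1cccc(-c2cc(C(=O)N3CCC(Cc4ccccc4)CC3)c3ccccc3n2)c1` has not yet been measured in this assay. Compared with compound 2 it carries 3-ethoxyphenyl in place of 4-methylphenyl on an aromatic carbon. Going by the values given here, with no measured step to draw on, the step from compound 2 to compound 4 is expected to be none beyond the scatter, a step that the limit leaves unreadable from compound 2 to compound 4, because all three measured values sit at the limit of > 20000 nM in this assay, at which 3 of the 3 values shown sit. Compound 4 is accordingly expected to give 40000 nM in this assay, with a range from 15000 nM to 120000 nM, and most probably reported as a limit rather than as a number.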

Compound 4, half-maximal cytotoxic concentration: > 20000 nM
Compound 4 gave a limit, no number; the forecaster's own chance of this, stated with the estimate: 85%; the middle value lies beyond the limit too.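

Compound 2 and compound 4 both sit at a limit rather than a number, so no step can be read between them: the limit of > 20000 nM in this assay, at which 4 of the 4 values shown sit. The compounds shown leave open how toxic any of them is in this assay, and whether 3-ethoxyphenyl in place of 4-methylphenyl on an aromatic carbon changes the read-out at all.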